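This account rests on a few compounds, and the source may have more. Where it says the series, first, only, none or still open, it means among the compounds named here.

Measured so far:
compound 1, `O=C(CCc1cccc2c1B(O)OC2)Nc1cccc2ccccc12`, 1200 nM;
compound 2, `O=C(CCc1cccc2c1B(O)OC2)Nc1cccc(-c2ccccc2)c1`, 12000 nM.

In an ADME assay on WI-38 cells (Homo sapiens) for cytotoxicity, read by MTT assay, with a stated time of 72 h (on this read-out higher numbers stand for weaker inhibition and lower numbers for stronger inhibition), compound 2 gives the highest of the two numbers recorded; compound 1 sits a good way below it, and that gap lies beyond the usual scatter. Compound 3, `O=C(CCc1cccc2c1B(O)OC2)Nc1cccc(-c2cccc(C(F)(F)F)c2)c1`, is not yet measured. It differs from compound 2 in one place: trifluoromethyl in place of hydrogen on an aromatic carbon. For the measured compounds named here, with no step between measured compounds to lean on, the account expects only a modest move, toward a lower number, a 2.0-fold lower number from compound 2 to compound 3 (0.30 log units; within the scatter), in this assay. For compound 3 the estimated value is 6000 nM, expected to lie between 2000 nM and 20000 nM.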

Compound 3, half-maximal inhibitory concentration: 23000 nM
Estimate against measurement, compound 3: 3.8-fold (0.58 log units) below, outside the stated range (above it).
By their numbers in this assay, from the lowest: compound 1; then compounds 2 and 3 (each within the scatter of the next).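

In this assay, trifluoromethyl in place of hydrogen on this aromatic carbon gives a 1.9-fold higher number from compound 2 to compound 3 (0.28 log units; within the scatter). For the compounds shown here, this is the first reading at this position, and the added group leaves compound 3 indistinguishable from compound 2 in this assay. For this one change, then, the position shows no effect that can be told from the scatter.

Going by these compounds, whether an amine, a carboxylic acid or a nitrile on the same carbon would give a step beyond the scatter remains open. No available evidence bears on this result.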